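A few compounds are considered here, and "the series" means these few. Any claim that something is new, unique, unknown or untested is made for them only; others in the source may bear on it.

Compound 1 `Cn1c(Sc2c(F)cc(C(=O)NO)cc2F)nnc1-c1cccs1`: > 1000 nM
Compound 2 `Cn1c(Sc2c(F)cc(C(=O)NO)cc2F)nnc1-c1cccc(CN2CCCCCC2)c1`: > 1000 nM

In an ADME assay on 697 cells (Homo sapiens) for cytotoxicity, with a stated time of 48 h (on this read-out lower numbers stand for stronger inhibition and higher numbers for weaker inhibition), compound 1 gives > 1000 nM, which is a limit of the assay and not a number. Compound 2 gives > 1000 nM, and this too is only a limit. Compound 3 `Cc1cc(-c2nnc(Sc3c(F)cc(C(=O)NO)cc3F)n2C)nn1C` keeps the core of compound 1 but carries 1,5-dimethyl-1H-pyrazol-3-yl in place of thiophen-2-yl on an aromatic carbon. Within the data shown here, no measured step shows what such a swap does, so the expectation rests only on (the limit of > 1000 nM in this assay, at which 2 of the 2 values shown sit). The expected change, a step that the limit leaves unreadable from compound 1 to compound 3, is none beyond the scatter. For compound 3 the estimate is 1500 nM, with an expected range from 700 nM to 5000 nM.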

Compound 3, half-maximal inhibitory concentration: > 1000 nM
Compound 3: no number, only a limit; the forecaster's own chance of this, stated with the estimate: 80%; the middle value does not contradict the limit.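

Among these compounds, compound 1 and compound 3 both sit at a limit of the assay, so no step between them can be read. The compounds shown leave open how strongly any of them acts on these cells, and whether swapping thiophen-2-yl for 1,5-dimethyl-1H-pyrazol-3-yl changes that at all.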